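Pyridyl amidrazone thiosemicarbazides: ring methyl on the azepane member

The source may report more compounds than this note shows. Statements on the series, on what has been measured and on what is new or still open speak of the compounds shown alone.

Measured so far:
- compound 1, `Cc1cccc(/C(N)=N/NC(=S)N2CCN(c3ccccn3)CC2)n1`, 83.8%
- compound 2, `N/C(=N\NC(=S)N1CCCCCC1)c1ccccn1`, 89%
- compound 3, `N/C(=N\NC(=S)N1CCCCC1)c1ccccn1`, 88.5%

All three were run in a functional assay on A-375 cells (Homo sapiens) for cytotoxicity, read by MTT assay, with a stated time of 72 h, tested at 100 uM; on this read-out higher numbers stand for more inhibition of growth at the one concentration tested and lower numbers for less inhibition of growth. Compound 2 holds the highest of the three numbers, yet its gap to compound 3 and its gap to compound 1 both lie within the usual scatter, so no ordering among the three can be claimed. Compound 1, which carries a methyl on the same ring and a different amine portion, sits in the same band.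

The next member, compound 4, `Cc1ccnc(/C(N)=N/NC(=S)N2CCCCCC2)c1`, is not yet measured. It differs from compound 2 by methyl in place of hydrogen on an aromatic carbon. Among the measured compounds shown here, no step between two measured compounds isolates this kind of change, so there is nothing to carry over; the only guidance is that every compound in the set so far sits in a narrow band near the top of the read-out. The step from compound 2 to compound 4 is therefore expected to be none beyond the scatter, in either direction, and is estimated as a number 2 percentage points lower from compound 2 to compound 4 (within the scatter). For compound 4 the expected value is 87%, with a range from 78% to 94%.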

Compound 4, percent growth inhibition at one concentration: 77%
Estimate against measurement, compound 4: 10 percentage points above, and the stated range ends above it.
By their numbers in this assay, from the lowest: compounds 4, 1, 3 and 2 (each within the scatter of the next, the first and the last beyond it).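

In this assay, among the compounds shown here, methyl in place of hydrogen on an aromatic carbon, opposite the ring nitrogen, gives a number 12 percentage points lower from compound 2 to compound 4 (beyond the scatter) and is the first single change that can be read, so this position is not indifferent to substitution when the amine portion is that of compound 2. Compound 1 also carries a ring methyl but differs from compound 2 in more than one place, so it gives no second reading of this change. Nothing available on these compounds accounts for the drop.

From the compounds shown here alone, it remains open whether an amine, a methoxy group or a chlorine atom on the same carbon would give a step of similar size. Going by these compounds, it is also open whether the same methyl would give a similar step with the amine portion of compound 3.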